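Amino to methyl on a shared core

The compounds below may be only part of what the source reports. "The series", "measured", "known", "first", "only" and "open" are said of these compounds alone.

Of the compounds shown here, two with a shared core have been measured so far in a physicochemical assay for acid dissociation. Compound 1 (`COc1ccc(CN(CCN(C)C)c2ccc(Cl)cn2)cc1`) gives 9.5. Compound 2 (`COc1ccc(CN(CCN(C)C)c2ccc(N)cn2)cc1`) gives 9.4, which stands level with compound 1 once the usual scatter of repeated measurements is allowed for. The next compound is compound 3 (`COc1ccc(CN(CCN(C)C)c2ccc(C)cn2)cc1`), and the change to it is methyl in place of amino on an aromatic carbon. In words, this is methyl in place of amino on an aromatic carbon, turning 5-aminopyridin-2-yl into 5-methylpyridin-2-yl.

Among the measured compounds shown here, only one measured step bears on this change: amino in place of chloro on an aromatic carbon, which gave a number 0.10 log units lower from compound 1 to compound 2 (within the scatter). For the measured compounds named here, that is thin evidence, and no measured compound yet carries methyl. Even so, the only swap of this kind stayed within the scatter, so no step beyond the scatter is expected in this assay. The expected size is no change at the digits printed from compound 2 to compound 3 (within the scatter). For compound 3 the estimate is 9.4, with an expected range from 9.1 to 9.7.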

Compound 3, acid dissociation constant: 9.6
Compound 3: middle estimate off by 0.20 log units, on the low side, and the stated range covers the measured number.
By their numbers in this assay, from the lowest: compounds 2, 1 and 3 (each within the scatter of the next).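

In this assay, putting methyl in place of amino gives a number 0.20 log units higher from compound 2 to compound 3 (within the scatter) and putting methyl in place of chloro gives a number 0.10 log units higher from compound 1 to compound 3 (within the scatter) on the same shared core. Three different groups have now been compared on this aromatic carbon, two atoms from the ring nitrogen and para to a large group, and none of the steps between them goes beyond the scatter, so the earlier single step between chloro and amino is no longer the only sign that this position tolerates a swap without a clear shift in the number. The comparison also covers a real difference in the groups themselves, as amino carries a hydrogen-bond donor and a hydrogen-bond acceptor while methyl carries neither, yet the numbers stay level, and nothing shown here gives a measured reason for that.

On these data alone, all three groups are small, each a single heavy atom, so it remains open whether a larger group on this carbon, such as a longer alkyl chain or a phenyl ring, would stay level too. A carboxylic acid or a nitrile here is equally untested among the compounds shown, and so is any of these three swaps on another carbon of the same ring.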